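The source may report more compounds than this note shows. Statements on the series, on what has been measured and on what is new or still open speak of the compounds shown alone.

Measured compounds in an in vitro functional assay on cells for agonist activity at Bombesin receptor subtype-3 (Mus musculus), read by luminescence and calcium flux; on this read-out higher numbers stand for an effect only at larger amounts of compound and lower numbers for an effect already at smaller amounts:
compound 1 `Cc1ccccc1Cc1cnc(CCc2ccc(-c3ccccc3C(=O)O)cc2)[nH]1`, compound 1 gives 9.3 nM
compound 2 `Cc1ccc(Cc2cnc(CCc3ccc(-c4ccccc4C(=O)O)cc3)[nH]2)cc1`, compound 2 gives 162 nM

Going by the values given here, compound 2 stands at the highest of the two numbers; its nearest neighbour is compound 1, reached by a 17-fold higher number from compound 1 to compound 2 (1.24 log units; beyond the scatter), which swaps 4-methylphenyl for 2-methylphenyl on the saturated chain carbon bound to an aromatic carbon and is the only measured step in the set.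

Compound 3 `COc1ccccc1Cc1cnc(CCc2ccc(-c3ccccc3C(=O)O)cc2)[nH]1` is not yet measured. Its difference from compound 2 is 2-methoxyphenyl in place of 4-methylphenyl on a saturated chain carbon bound to an aromatic carbon. This step bears a close relation to the measured one: both compound 1 and compound 3 carry a group with its substituent in the 2-position of the phenyl, whereas compound 2 carries it in the 4-position. Among the compounds with values here, the one step available, a 17-fold higher number from compound 1 to compound 2 (1.24 log units; beyond the scatter), was large, so the return to a 2-substituted phenyl is expected to bring a large step back toward lower numbers in this assay, of roughly the size seen for compound 1; the unmeasured swap of methyl for methoxy adds uncertainty. The estimated step is an 11-fold lower number from compound 2 to compound 3 (1.03 log units; beyond the scatter), and compound 3 is expected to give 15 nM, in the range 5 nM to 60 nM.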

Compound 3, half-maximal effective concentration: 163 nM
For compound 3 the middle estimate is 11-fold (1.04 log units) below the measured one; measured number outside the range, above it.
By their numbers in this assay, from the lowest: compound 1; then compounds 2 and 3 (each within the scatter of the next).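

In this assay the low number of compound 1 does not carry over to every group named as a 2-substituted phenyl: 2-methoxyphenyl in place of 4-methylphenyl on the saturated chain carbon gives a 1.0-fold higher number from compound 2 to compound 3 (0.00 log units; within the scatter) and so leaves the two groups indistinguishable at this place. The exchange of methoxy for methyl on an aromatic carbon, with the rest of the molecule held, gives an 18-fold higher number from compound 1 to compound 3 (1.24 log units; beyond the scatter) and matches in printed size the earlier 17-fold higher number from compound 1 to compound 2 (1.24 log units; beyond the scatter), so among these three compounds the low number belongs to 2-methylphenyl alone, and compound 3 goes against any reading based on the substitution pattern of the phenyl by itself. Nothing available accounts for the gap between methyl and methoxy at this place.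

Open, on these data alone, is whether the low number of compound 1 extends to other groups on this phenyl, such as ethyl or chlorine, or is lost with an unsubstituted phenyl. Also open, as far as these compounds go, is what 4-methoxyphenyl would give on the same core, which would complete the comparison of methyl and methoxy across both named substitution patterns.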